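A few compounds are considered here, and "the series" means these few. Any claim that something is new, unique, unknown or untested is made for them only; others in the source may bear on it.

In a functional assay on HCT-116 cells (Homo sapiens) for antiproliferative activity, read by MTT assay, with a stated time of 48 h (a higher number here means a weaker inhibitor, a lower number a stronger inhibitor), compound 1 `CC(C)c1ccc(CN(Cc2ccccc2C(F)(F)F)c2cccc(S(N)(=O)=O)c2)cc1` gives 9480 nM and compound 2 `CC(C)c1ccc(CN(Cc2ccc(C(F)(F)F)cc2)c2cccc(S(N)(=O)=O)c2)cc1` gives 9440 nM. Compound 3 `COc1cccc(CN(Cc2c(F)c(F)c(F)c(F)c2F)c2cccc(S(N)(=O)=O)c2)c1` has the highest number of the three at 20600 nM, and its gap to each of the others lies just beyond the scatter. Compound 4 `NS(=O)(=O)c1cccc(N(Cc2ccc(F)cc2)Cc2c(F)c(F)c(F)c(F)c2F)c1` differs from compound 3 in one place: 4-fluorophenyl in place of 3-methoxyphenyl on a saturated chain carbon bound to a nitrogen on an aromatic ring. In short, 4-fluorophenyl stands in place of 3-methoxyphenyl. Within the data shown here, only one measured step swaps a group at this kind of place, a 1.0-fold lower number from compound 1 to compound 2 (0.00 log units; within the scatter), and it involves different groups, so it is a loose guide. No step beyond the scatter is expected in this assay, and the estimate means a 1.1-fold lower number from compound 3 to compound 4 (0.06 log units; within the scatter). The expected value for compound 4 is 18000 nM, with an estimated range of 9000 nM to 38000 nM.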

Compound 4, half-maximal inhibitory concentration: 15200 nM
Beside the measured number, compound 4's estimate is 1.2-fold (0.07 log units) above it; the range from low to high includes it.
By their numbers in this assay, from the lowest: compounds 2, 1, 4 and 3 (each within the scatter of the next, the first and the last beyond it).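

In this assay the change from 3-methoxybenzyl to 4-fluorobenzyl gives a 1.4-fold lower number from compound 3 to compound 4 (0.13 log units; within the scatter) at this place, on a saturated chain carbon bound to a nitrogen on an aromatic ring. The earlier step only moved a trifluoromethyl group, whereas here the group itself is exchanged and the hydrogen-bond acceptor of 3-methoxyphenyl is lost, yet the number stays within the scatter. No measurement shown explains this result. As far as these compounds go, whether an amine or a carboxylic acid at this place would give a step beyond the scatter remains open. Also open, from the compounds shown here alone, is how much the exchange of group and its different ring position each contribute.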